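Longer Chain on the Amine Nitrogen of Compound 2

This account rests on a few compounds, and the source may have more. Where it says the series, first, only, none or still open, it means among the compounds named here.

Measured so far:
compound 1 `CC(C)N(C)/N=N/c1ccc(C(N)=O)cc1` — 3.17
compound 2 `C=CCN(C)/N=N/c1ccc(C(N)=O)cc1` — 3.38

The two compounds share one core and differ only in the group on an amine nitrogen. In a functional assay on L1210 cells (Mus musculus) for antiproliferative activity (on this read-out higher numbers stand for higher potency (the scale is a negative logarithm) and lower numbers for lower potency), compound 1 gives 3.17 and compound 2 gives 3.38. Among the compounds with values here, the single measured step, a number 0.21 log units higher from compound 1 to compound 2 (within the scatter), shows that exchanging one small group for another left the read-out essentially unchanged. Compound 2 holds the higher of the two numbers, but its nearest neighbour, compound 1, sits within the scatter, so no order between them can be claimed.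

Compound 3 `CCCCCCCCN(C)/N=N/c1ccc(C(N)=O)cc1` has not been measured. It differs from compound 2 by heptyl in place of vinyl on a saturated chain carbon bound to an amine nitrogen. Within the data shown here, the only step available, a number 0.21 log units higher from compound 1 to compound 2 (within the scatter), concerns groups of similar size and bears on this much longer chain only loosely, so the expectation rests thinly. Compound 3 is therefore estimated at 3.6, with a range from 3 to 4.2. The expected step of a number 0.22 log units higher from compound 2 to compound 3 (within the scatter) is modest and uncertain in direction.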

Compound 3, logarithm of the reciprocal of the active concentration, log(1/C): 2.84
For compound 3 the middle estimate is 0.76 log units above the measured one; measured number below the stated range.
By their numbers in this assay, from the lowest: compound 3; then compounds 1 and 2 (each within the scatter of the next).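

The exchange of vinyl for heptyl on a saturated chain carbon bound to an amine nitrogen gives a number 0.54 log units lower from compound 2 to compound 3 (beyond the scatter) in this assay. Within the data shown here, this is the first step at this position to pass beyond the scatter, so the position is not indifferent to what it carries, which the exchange between compound 1 and compound 2 could not show. Nothing at hand explains the fall in the number.

A single long chain leaves open how the read-out follows chain length, and a butyl or a hexyl chain at this position would show whether the fall comes gradually or only with the longest chain. As far as these compounds go, it also remains open whether a chain of the same length ending in a hydroxyl group or a carboxylic acid would give a similar number.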